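Fluoro for Methyl on a Weak Starting Compound

This account rests on a few compounds, and the source may have more. Where it says the series, first, only, none or still open, it means among the compounds named here.

Compound 1, `Cc1ccc(N2CCN(C(=O)c3oc(C)nc3-c3ccccc3)CC2)cc1`, was tested in a functional assay on HL-60 cells (Homo sapiens) for inhibition, read by MTT assay, with a stated time of 72 h; a higher number here means a weaker inhibitor, a lower number a stronger inhibitor. In this assay compound 1 gives > 1000 nM, which is a limit of the assay rather than a number. Compound 1 therefore sits at the weaker edge of the numbers shown, namely (the limit of > 1000 nM in this assay, at which 1 of the 2 values shown sits). Within the data shown here, a second compound, compound 2 `CCc1nc(-c2ccccc2F)c(C(=O)N2CCN(c3cccc(OC)c3)CC2)o1`, differs from compound 1 in several places at once, so no single step links the two. In this assay compound 2 gives 607 nM. The unmeasured compound 3, `Cc1nc(-c2ccccc2)c(C(=O)N2CCN(c3ccc(F)cc3)CC2)o1`, differs from compound 1 in just one place: fluoro in place of methyl on an aromatic carbon. Among the measured compounds shown here, no measured step of this kind exists here, so the change is expected to stay within the usual scatter, in either direction, and the expected step is a step that the limit leaves unreadable from compound 1 to compound 3. Compound 3 is accordingly estimated at 1500 nM, with a range from 400 nM to 6000 nM, and a fair chance that the assay again reports only a limit.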

Compound 3, half-maximal inhibitory concentration: > 1000 nM
Compound 3: only a limit was reported; the forecaster's own chance of this, stated with the estimate: 55%; the middle value does not contradict the limit.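

In this assay compound 3 gives > 1000 nM, which is a limit of the assay and not a number. Among these compounds, compound 1 is also reported only as a limit, so no step between compound 1 and compound 3 can be read: the limit of > 1000 nM in this assay, at which 2 of the 3 values shown sit. The compounds shown leave open how strongly either compound actually inhibits, and so what fluoro in place of methyl does here.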